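The source may hold more compounds than are shown below. What is called first, only, known or untested is meant among the compounds shown, and "the series" means these compounds.

Of the compounds shown here, three sharing one core have been measured in a functional assay on PC-3 cells (Homo sapiens) for inhibition, read by sulforhodamine B assay, with a stated time of 48 h; a higher number here means a weaker inhibitor of growth, a lower number a stronger inhibitor of growth. Compound 1 `CC1(/C=C/c2ccccc2)C=CC(=O)O1` gives 86900 nM, compound 2 `COc1ccc(/C=C/C2(C)C=CC(=O)O2)cc1OC` gives 176000 nM, and compound 3 `CC1(/C=C/c2cccc(O)c2)C=CC(=O)O1` gives 98800 nM, which lies within the scatter of both others. Compound 4 `COc1cccc(/C=C/C2(C)C=CC(=O)O2)c1` differs from compound 3 by methyl in place of hydrogen on an oxygen on an aromatic ring, or hydroxy to methoxy. Going by the values given here, the one measured step that bears on this is a 1.1-fold higher number from compound 1 to compound 3 (0.06 log units; within the scatter), where hydroxy replaced hydrogen on an aromatic carbon, and it stayed within the scatter. No step beyond the scatter is therefore expected in this assay, only a possible small drift towards a higher number. The expected step is a 1.2-fold higher number from compound 3 to compound 4 (0.08 log units; within the scatter). The estimated value for compound 4 is 120000 nM, with an expected range of 70000 nM to 200000 nM.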

Compound 4, concentration for total growth inhibition: 31600 nM
Estimate against measurement, compound 4: 3.8-fold (0.58 log units) above, outside the stated range (below it).
By their numbers in this assay, from the lowest: compound 4; then compounds 1, 3 and 2 (each within the scatter of the next, the first and the last beyond it).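

In this assay, methyl in place of hydrogen on the oxygen on the aromatic ring gives a 3.1-fold lower number from compound 3 to compound 4 (0.50 log units; beyond the scatter), so this oxygen's substituent matters although the earlier hydroxy change, a 1.1-fold higher number from compound 1 to compound 3 (0.06 log units; within the scatter), stayed within the scatter. The methoxy also separates compound 4 from the unsubstituted compound, with a 2.8-fold lower number from compound 1 to compound 4 (0.44 log units; beyond the scatter), and hydrogen in place of a methoxy on an aromatic carbon gives a 5.6-fold lower number from compound 2 to compound 4 (0.75 log units; beyond the scatter), so adding methoxy does not lower the number in every case. No evidence is available to explain these differences. On these data alone, whether an ethoxy or an amine at this place would also give a lower number remains open.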